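The compounds below may be only part of what the source reports. "The series", "measured", "known", "first", "only" and "open" are said of these compounds alone.

Measured compounds:
compound 1, `COc1ccc(Cl)cc1-c1cc(Nc2ccc(Cl)cc2)nc(N)n1`: 150 nM
compound 2, `CCOc1ccc(Br)cc1-c1cc(Nc2ccc(B(O)O)cc2)nc(N)n1`: 200 nM

In a functional assay on K562 cells (Homo sapiens) for inhibition (a higher number here means a weaker inhibitor, a lower number a stronger inhibitor), compound 2 gives 200 nM, the highest of the two numbers, though compound 1 lies within the scatter of it. Compound 3, `CCOc1ccc(Br)cc1-c1cc(Nc2cccc(C#N)c2)nc(N)n1`, differs from compound 2 as follows: a group of 8 heavy atoms (7 carbon, 1 nitrogen; one six-membered aromatic ring of carbon only) in place of a group of 9 heavy atoms (6 carbon, 1 boron, 2 oxygen; one six-membered aromatic ring of carbon only), on a nitrogen on an aromatic ring. For the measured compounds named here, no step between measured compounds is available for this change, so nothing here shows how the group on that nitrogen moves the number. The expected step is no change at the digits printed from compound 2 to compound 3 (within the scatter), no larger than the scatter, in no set direction. Compound 3 is therefore expected to give about 200 nM, between 70 nM and 600 nM.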

Compound 3, half-maximal inhibitory concentration: 350 nM
For compound 3 the middle estimate is 1.8-fold (0.24 log units) below the measured one; the range from low to high includes it.
By their numbers in this assay, from the lowest: compounds 1, 2 and 3 (each within the scatter of the next, the first and the last beyond it).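

In this assay the swap of the boron-containing group on the nitrogen for 3-cyanophenyl gives a 1.8-fold higher number from compound 2 to compound 3 (0.24 log units; within the scatter) and so stays within the scatter. This position therefore accepts a group without boron, carrying a nitrile instead, with no change that can be told from the scatter.

From the compounds shown here alone, what an amine or a carboxylic acid on that ring would do stays open, as does the effect of an unsubstituted phenyl group at the same nitrogen. No measurement shown here accounts for the result.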